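Hydroxymethyl on the core ring carbon of compound 1

The source may hold more compounds than are shown below. What is called first, only, known or untested is meant among the compounds shown, and "the series" means these compounds.

Measured so far:
compound 1, `CCCc1cccc(=O)n1Cc1ccc(-c2ccccc2-c2nn[nH]n2)cc1`: 1.1 mg/kg
compound 2, `CCCc1cc(O)cc(=O)n1Cc1ccc(-c2ccccc2-c2nn[nH]n2)cc1`: 0.048 mg/kg

In a functional assay on the whole organism with Rattus norvegicus as the target (a lower number here means that less compound is needed, a higher number that more compound is needed for the effect), compound 1 gives 1.1 mg/kg, the higher of the two numbers measured in this series; compound 2 gives 0.048 mg/kg. Among the measured compounds shown here, the single measured step, a 23-fold lower number from compound 1 to compound 2 (1.36 log units; beyond the scatter), comes from placing a hydroxy group on an aromatic carbon of the shared core, opposite the ring nitrogen.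

Compound 3, `CCCc1cc(CO)cc(=O)n1Cc1ccc(-c2ccccc2-c2nn[nH]n2)cc1`, is not yet measured. It differs from compound 1 by hydroxymethyl in place of hydrogen on an aromatic carbon, the same aromatic carbon that carries the hydroxy group in compound 2. For the measured compounds named here, the hydroxymethyl group, like the hydroxy group, brings one hydrogen-bond donor and one hydrogen-bond acceptor, but no step with this group has been measured, so the size of its effect is open. Given the step from compound 1 to compound 2 (a 23-fold lower number from compound 1 to compound 2 (1.36 log units; beyond the scatter)), a lower number than that of compound 1 is expected for a group of this kind at this carbon, though a smaller one, since the only guide is a different group. The estimate for compound 3 is 0.3 mg/kg, with a range of 0.07 mg/kg to 1.3 mg/kg, which is expected to mean a 3.7-fold lower number from compound 1 to compound 3 (0.56 log units; beyond the scatter).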

Compound 3, dose for 50% inhibition: 0.3 mg/kg
The estimate for compound 3 equals the measured number at the digits printed, within the range that was stated.
By their numbers in this assay, from the lowest: compound 2; then compound 3; then compound 1.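

In this assay, the lower number at the carbon opposite the ring nitrogen is not confined to hydroxy, since hydroxymethyl in place of hydrogen also lowers it (a 3.7-fold lower number from compound 1 to compound 3 (0.56 log units; beyond the scatter)). The two groups are not interchangeable at this carbon: replacing hydroxy with hydroxymethyl gives a step beyond the scatter (a 6.3-fold higher number from compound 2 to compound 3 (0.80 log units; beyond the scatter)), which leaves compound 2 with the lowest number of the three and compound 3 in the middle. No measurement bears on why the two groups differ.

Going by these compounds, with only hydroxy and hydroxymethyl compared against hydrogen at this carbon, it remains open how far the number would move with an amine, a carboxylic acid or a longer chain such as hydroxyethyl. Also open, on these data alone, is whether hydroxy and hydroxymethyl would keep this order, and a gap of similar size, on another carbon of the shared core or with a chain other than propyl on it.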